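Swapping the amine tail: two rings out, a methoxybenzyl in

The source may report more compounds than this note shows. Statements on the series, on what has been measured and on what is new or still open speak of the compounds shown alone.

Within the data shown here, compound 2, `CC(C)Sc1nnc(-c2c(CN3CCC(N4CCCC4)CC3)c3ccccc3n2C)n1-c1ccccc1`, gives 5.16 in a physicochemical assay for lipophilicity (on this read-out lower numbers stand for lower lipophilicity and higher numbers for higher lipophilicity), the lowest of the two numbers measured so far. Among the measured compounds shown here, the only comparison available is compound 1, `CC1CCCN(Cc2c(-c3nnc(SC(C)C)n3-c3ccccc3)n(C)c3ccccc23)C1`, which gives 6.03 in this assay; the change a number 0.87 log units lower from compound 1 to compound 2 (beyond the scatter) shows that widening the saturated amine with a second ring containing nitrogen lowered the read-out.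

Compound 3, `COc1ccc(CNCc2c(-c3nnc(SC(C)C)n3-c3ccccc3)n(C)c3ccccc23)cc1`, is not yet measured. It differs from compound 2 by (4-methoxybenzyl)amino in place of 4-(pyrrolidin-1-yl)piperidin-1-yl on a saturated chain carbon bound to an aromatic carbon. The incoming group carries a six-membered aromatic ring of carbon only and one hydrogen-bond donor, unlike either tail measured so far, so the earlier step bears on it only loosely. Since compound 1 with a single saturated ring sits at 6.03, compound 3 is expected to move back up, with an estimated a number 0.74 log units higher from compound 2 to compound 3 (beyond the scatter). The estimate for compound 3 is 5.9, between 5.3 and 6.5.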

Compound 3, partition coefficient: 6.27
For compound 3 the middle estimate is 0.37 log units below the measured one, and the stated range covers the measured number.
By their numbers in this assay, from the lowest: compound 2; then compounds 1 and 3 (each within the scatter of the next).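

In this assay, the change of tail gives a number 1.11 log units higher from compound 2 to compound 3 (beyond the scatter) and so shows that this saturated chain carbon bound to an aromatic carbon can also carry a tail with a six-membered aromatic ring and a hydrogen-bond donor, with a clear shift in the read-out. The comparison with the single-ring tail gives a number 0.24 log units higher from compound 1 to compound 3 (within the scatter) and so does not separate (4-methoxybenzyl)amino from 3-methylpiperidin-1-yl, which leaves 4-(pyrrolidin-1-yl)piperidin-1-yl as the only one of the three tails that stands apart. Nothing here offers independent evidence on what lies behind these differences.

As far as these compounds go, it remains open whether a morpholin-4-yl tail would sit with compound 2 or with compounds 1 and 3. The compounds shown also cannot say what the methoxy group contributes, and a plain benzylamino tail would address that question.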